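The source may report more compounds than this note shows. Statements on the series, on what has been measured and on what is new or still open speak of the compounds shown alone.

Compound 1 `O=C(O)C1CC1c1ccc(NCc2cccc(Oc3ccccc3)c2)cc1` gives the lower of the two numbers obtained so far in a functional assay for agonist activity at Free fatty acid receptor 1 (Homo sapiens) (a lower number here means that less compound is needed, a higher number that more compound is needed for the effect), where compound 1 gives 50.1 nM. Compound 2 `O=C(O)CCc1cccc(NCc2cccc(Oc3ccccc3)c2)c1`, which carries its acid on a different part of the shared core, gives 398 nM in this assay, a gap that lies beyond the scatter, so compound 1 stands as the stronger of the two measured agonists.

Compound 3 `CC(C(=O)O)c1ccc(NCc2cccc(Oc3ccccc3)c2)cc1` differs from compound 1 in one place: 1-carboxyethyl in place of 2-carboxycyclopropyl on an aromatic carbon. The acid is thus kept, but the three-membered ring that holds it in compound 1 is opened into a shorter, unconstrained side chain on the same aromatic carbon.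

Within the data shown here, no measured pair shows this particular change, so the size of the step is uncertain. The expectation is a modest rise in the number, a 2.6-fold higher number from compound 1 to compound 3 (0.41 log units; beyond the scatter), on the view that compound 1 sets the reference at 50.1 nM and that the opened chain may fall somewhat short of it. Compound 3 is therefore estimated at 130 nM in this assay, within a range of 40 nM to 450 nM.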

Compound 3, half-maximal effective concentration: 16600 nM
The estimate for compound 3 lay 130-fold (2.11 log units) below the measured number; measured number above the stated range.
By their numbers in this assay, from the lowest: compound 1; then compound 2; then compound 3.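

On this aromatic carbon, para to a large group, the acid-bearing group proves far from interchangeable: in this assay, 1-carboxyethyl in place of 2-carboxycyclopropyl gives a 330-fold higher number from compound 1 to compound 3 (2.52 log units; beyond the scatter). Both groups count one hydrogen-bond donor, one hydrogen-bond acceptor and no net charge, so keeping the carboxylic acid on this carbon and matching these counts does not preserve the number. No measurement among those shown accounts for the size of this step.

On these data alone, it remains open which part of the 2-carboxycyclopropyl group matters, and whether a 2-carboxyethyl chain, a carboxymethyl group or a 1-carboxycyclopropyl group on the same carbon would stay close to compound 1 or fall towards compound 3. Also open, as far as these compounds go, is how a tetrazole in place of the carboxylic acid would fare.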